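Removing one fluoro from compound 1

This account rests on a few compounds, and the source may have more. Where it says the series, first, only, none or still open, it means among the compounds named here.

Compound 1 `CCNCC1CCN(c2c(F)cc3c(=O)c(C(=O)O)cn(CC)c3c2F)C1` gives 160 ug/mL
Compound 2 `CCNCC1CCN(c2c(F)cc3c(=O)c(C(=O)O)cn(C4CC4)c3c2F)C1` gives 11 ug/mL; 11 ug/mL; 11 ug/mL; 11 ug/mL (4 entries)

Both values come from a functional assay on V79 cells (Cricetulus griseus) for cytotoxicity, read by colony formation; a lower number here means a stronger inhibitor, a higher number a weaker inhibitor. Of the two, compound 1 stands at the higher number, 160 ug/mL, and one further entry for compound 1 offers no single number. Compound 3 `CCNCC1CCN(c2cc3c(cc2F)c(=O)c(C(=O)O)cn3CC)C1` keeps the core of compound 1 and its 3-((ethylamino)methyl)pyrrolidin-1-yl group, with one change: hydrogen in place of fluoro on an aromatic carbon. Among the compounds with values here, no measured pair shows this exchange, so the expectation in this assay rests on compound 1 alone, at 160 ug/mL. The expected move, a 1.3-fold higher number from compound 1 to compound 3 (0.10 log units; within the scatter), is small, with none beyond the scatter foreseen and, if anything, a drift towards a weaker inhibitor. Compound 3 is estimated at 200 ug/mL, with an expected range from 70 ug/mL to 500 ug/mL.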

Compound 3, half-maximal inhibitory concentration: 310 ug/mL
Compound 3: the middle estimate sits 1.6-fold (0.19 log units) below what was measured, and the stated range covers the measured number.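

In this assay, hydrogen in place of fluoro on this aromatic carbon, ortho to the 3-((ethylamino)methyl)pyrrolidin-1-yl group, gives a 1.9-fold higher number from compound 1 to compound 3 (0.29 log units; within the scatter) and so stays within the scatter. On the core of compound 1, with its ethyl group on the ring nitrogen, the two numbers therefore cannot be told apart, and this single pair shows no need for the fluoro at this place in this read-out. No measurement of any other property is at hand to account for this result.

As far as these compounds go, whether the same exchange behaves alike in compound 2, which carries a cyclopropyl group in place of the ethyl group, remains open. So does the outcome of putting a chlorine, a methyl or a methoxy group on this aromatic carbon instead of fluoro or hydrogen.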